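From nitro to hydrogen on the shared core

The compounds below may be only part of what the source reports. "The series", "measured", "known", "first", "only" and "open" are said of these compounds alone.

Among the measured compounds shown here, in a functional assay on HL-60 cells (Homo sapiens) for cytotoxicity, read by luminescence and CellTiter-Glo, with a stated time of 3 days (a higher number here means a weaker inhibitor, a lower number a stronger inhibitor), compound 1 `O=C(Nc1ccc(C(F)(F)F)cc1)c1cc(F)ccc1O` gives 490 nM and compound 2 `O=C(Nc1ccc([N+](=O)[O-])cc1)c1cc(F)ccc1O` gives 520 nM, so compound 2 stands level with the only other measured compound. Compound 3 `O=C(Nc1ccccc1)c1cc(F)ccc1O` has hydrogen in place of nitro on an aromatic carbon, para to a large group: hydrogen in place of nitro on an aromatic carbon.

For the measured compounds named here, one measured step bears on this change: a 1.1-fold higher number from compound 1 to compound 2 (0.03 log units; within the scatter), with nitro in place of trifluoromethyl on an aromatic carbon. That step exchanges one group for another, and this assay does not separate the two. Going by the values given here, no measured compound has hydrogen at this place, so the size of the change from nitro to hydrogen remains unmeasured, and the evidence for its direction is thin. Both measured compounds carry a group there and compound 3 does not, so a moderate move to a higher number is expected, though no step beyond the scatter remains possible.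

The expected change in this assay is a 2.3-fold higher number from compound 2 to compound 3 (0.36 log units; beyond the scatter). For compound 3, the estimate is 1200 nM, with an expected range of 500 nM to 4000 nM.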

Compound 3, half-maximal inhibitory concentration: > 10000 nM
Compound 3 ended at the assay's limit; the forecaster's own chance of this, stated with the estimate: 5%; at least 8.3-fold (0.92 log units) between middle value and limit.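

Hydrogen in place of nitro, para to a large group, gives an at least 19-fold higher number from compound 2 to compound 3 (1.28 log units; beyond the scatter) in this assay, and hydrogen in place of trifluoromethyl gives an at least 20-fold higher number from compound 1 to compound 3 (1.30 log units; beyond the scatter). The earlier pair showed only that nitro and trifluoromethyl could not be told apart, a 1.1-fold higher number from compound 1 to compound 2 (0.03 log units; within the scatter); the new steps show that this position is not indifferent, since in these three compounds the two that carry a group on this aromatic carbon stand well clear of the one that carries hydrogen. Compound 3 gives > 10000 nM, which is a limit of the assay and not a number: the limit of > 10000 nM in this assay, at which 1 of the 3 values shown sits.

From the compounds shown here alone, how far compound 3 lies past that limit stays open, so both new steps give a minimum size and no exact one. Going by these compounds, with only nitro and trifluoromethyl as substituents here, it is also open which groups at this place hold the value of compound 1 and compound 2, and an amine, a methoxy group or a single chlorine on this carbon would begin to answer that.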